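Aryl piperazine swap on the shared nitrile core

This account rests on a few compounds, and the source may have more. Where it says the series, first, only, none or still open, it means among the compounds named here.

Measured compounds:
- compound 1 `N#Cc1c(-c2ccc(Oc3ccccc3)cc2)ccn2c(CC(F)(F)F)cnc12`: 186 nM
- compound 2 `CCCc1cnc2c(C#N)c(N3CCN(c4ccccc4)CC3)ccn12`: 977 nM
- compound 3 `CCc1cnc2c(C#N)c(N3CCN(c4ncccn4)CC3)ccn12`: > 3160 nM

In a functional assay on CHO cells with metabotropic glutamate receptor 2 (Homo sapiens) as the target, read by GTPgammaS binding (a lower number here means that less compound is needed, a higher number that more compound is needed for the effect), compound 2 gives 977 nM, the highest of the two numbers recorded. The nearest number belongs to compound 1, which gives 186 nM, a gap that lies beyond the usual scatter. The value of compound 3 is a limit of this assay and not a number; this is the point described by the limit of > 3160 nM in this assay, at which 1 of the 3 values shown sits.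

Compound 4 `CCCc1cnc2c(C#N)c(N3CCN(c4nc(C)cc(C)n4)CC3)ccn12` differs from compound 2 in one place: 4,6-dimethylpyrimidin-2-yl in place of phenyl on an amine nitrogen in a ring. Among the compounds with values here, no measured pair isolates exactly this change, so its size must be judged from the spread of the three values alone. Compound 2, with phenyl on the ring nitrogen, is itself the highest number, and compound 3, which carries a pyrimidine at the same place of its own core, reaches only the limit.

The step from compound 2 to compound 4 is therefore expected to run toward a higher number in this assay, as a 3.1-fold higher number from compound 2 to compound 4 (0.49 log units; beyond the scatter). Compound 4 is expected to give about 3000 nM, with the range 1000 nM to 9000 nM, and a fair chance that only a limit is returned.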

Compound 4, half-maximal effective concentration: 646 nM
Beside the measured number, compound 4's estimate is 4.6-fold (0.67 log units) above it; the measured number lies below the stated range.
By their numbers in this assay, from the lowest: compound 1; then compounds 4 and 2 (each within the scatter of the next). At a limit, above all of these: compound 3.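

In this assay, placing 4,6-dimethylpyrimidin-2-yl in place of phenyl on the amine nitrogen in the ring gives a 1.5-fold lower number from compound 2 to compound 4 (0.18 log units; within the scatter), so on this core the place accepts the larger aromatic ring, with its hetero atoms and methyl groups, without a change that can be told from the scatter. Within the data shown here, this is the first pair that isolates a change at this place, and it shows that a ring of carbon only is not needed there for compound 4 to return a number rather than a limit. Compound 3, which differs from compound 4 in more than one place, remains a limit of the assay and not a number: the limit of > 3160 nM in this assay, at which 1 of the 4 values shown sits.

What separates compound 3 from compound 4 cannot be read: no pair shown isolates the ethyl chain against the propyl chain, or the pyrimidine with methyl groups against the one without them. Also open, going by these compounds, is whether a pyridine, a methoxy-bearing phenyl or a longer chain on the shared core would move the number beyond the scatter.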